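The source may report more compounds than this note shows. Statements on the series, on what has been measured and on what is new or still open speak of the compounds shown alone.

Measured in a functional assay on DU-145 cells (Homo sapiens) for inhibition, read by MTT assay, with a stated time of 24 h; a higher number here means a weaker inhibitor, a lower number a stronger inhibitor:
compound 1 `CCOC(=O)C1=Cc2ccccc2OC1(OCc1cc(-c2ccc(F)cc2F)no1)C(F)(F)F` — for compound 1 the assay reports only a limit, > 150000 nM.
compound 2 `O=C(O)C1=Cc2ccccc2OC1(OCc1cc(-c2ccc([N+](=O)[O-])cc2)no1)C(F)(F)F` — compound 2 gives 100000 nM.
compound 3 `O=C(O)C1=Cc2ccccc2OC1(OCc1cc(-c2ccc3ccccc3c2)no1)C(F)(F)F` — compound 3 gives 141000 nM.

Among the compounds with values here, compound 2 holds the lowest of the two numbers in this assay, but its only numbered neighbour is close: the step of a 1.4-fold higher number from compound 2 to compound 3 (0.15 log units; within the scatter) shows no difference beyond the scatter.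

Compound 4 `CCOC(=O)C1=Cc2ccccc2OC1(OCc1cc(-c2ccc([N+](=O)[O-])cc2)no1)C(F)(F)F` differs from compound 2 by ethyl in place of hydrogen on an oxygen next to a carbonyl group. Within the data shown here, no measured step covers this change; the single measured step concerns a different part of the molecule and does not bear on it. Among the measured compounds shown here, the only pointer is compound 1, which sits at the limit (the limit of > 150000 nM in this assay, at which 1 of the 3 values shown sits). Compound 4 is therefore expected near the top of the measurable window, with a fair chance of a limit. Compound 4 is estimated at 150000 nM, range 70000 nM to 350000 nM. This means the step of a 1.5-fold higher number from compound 2 to compound 4 (0.18 log units; within the scatter) is expected, a weakening if anything.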

Compound 4, half-maximal inhibitory concentration: > 150000 nM
Compound 4: only a limit was reported; the forecaster's own chance of this, stated with the estimate: 50%; the middle value lies on the limit itself.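

In this assay, the change from carboxy to ethoxycarbonyl gives an at least 1.5-fold higher number from compound 2 to compound 4 (0.17 log units; that floor lies within the scatter), so only a floor is available and the true size of the change cannot be read. The step between compound 1 and compound 4 cannot be read either, as both values are limits. With the nitrophenyl-bearing compound 4 also reported only as a limit, both ethoxycarbonyl compounds shown now end there: the limit of > 150000 nM in this assay, at which 2 of the 4 values shown sit.

Open, as far as these compounds go, is how far compound 4 lies from compound 2. Also open, from the compounds shown here alone, is whether a primary amide or a methyl ester in place of the carboxylic acid would give a number rather than a limit.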